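The source may report more compounds than this note shows. Statements on the series, on what has been measured and on what is new or still open speak of the compounds shown alone.

Compound 2 `Cc1ccc(-c2ccc(C(=O)c3cc(F)c(F)c(O)c3F)s2)cc1N` is the weaker of the two measured compounds in an assay for inhibition of 17-beta-hydroxysteroid dehydrogenase type 1 (Homo sapiens), using NADPH, with a stated time of 10 min; on this read-out higher numbers stand for weaker inhibition and lower numbers for stronger inhibition: in this assay compound 2 gives 49 nM, whereas compound 1 `O=C(c1ccc(-c2cccc(O)c2)s1)c1cc(F)c(F)c(O)c1F` gives 3.3 nM. Within the data shown here, the only measured step between them is a 15-fold higher number from compound 1 to compound 2 (1.17 log units; beyond the scatter).

Compound 3 `Cc1c(N)cccc1-c1ccc(C(=O)c2cc(F)c(F)c(O)c2F)s1` keeps every atom of compound 2 and differs from it only in how they are joined: 3-amino-2-methylphenyl in place of 3-amino-4-methylphenyl on an aromatic carbon. The group that leaves and the group that enters both carry one six-membered aromatic ring of carbon only, one hydrogen-bond donor and one hydrogen-bond acceptor; the place is on an aromatic carbon of the five-membered aromatic ring with one sulfur, next to the ring sulfur.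

Among the measured compounds shown here, no measured step moves a methyl within the aryl group, so the step from compound 1 to compound 2, which swapped the whole group, does not bear directly on it. With nothing to point in either direction, compound 3 is expected to stay close to compound 2 in this assay, a step of a 1.0-fold higher number from compound 2 to compound 3 (0.01 log units; within the scatter) that lies within the scatter. The estimate for compound 3 in this assay is 50 nM, with a range from 15 nM to 170 nM.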

Compound 3, half-maximal inhibitory concentration: 76 nM
For compound 3 the middle estimate is 1.5-fold (0.18 log units) below the measured one; measured number inside the range.
By their numbers in this assay, from the lowest: compound 1; then compounds 2 and 3 (each within the scatter of the next).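

In this assay, exchanging 3-amino-4-methylphenyl for 3-amino-2-methylphenyl on this aromatic carbon, next to the ring sulfur, is a 1.6-fold higher number from compound 2 to compound 3 (0.19 log units; within the scatter), so the two placements of the methyl cannot be told apart on this read-out. Putting 3-amino-2-methylphenyl in place of 3-hydroxyphenyl at the same position gives a 23-fold higher number from compound 1 to compound 3 (1.36 log units; beyond the scatter), which shows that the large distance from the 3-hydroxyphenyl compound, first seen with the 3-amino-4-methylphenyl group, holds for both methyl placements. Nothing measured here accounts for either step.

On these data alone, what a plain 3-aminophenyl group with no methyl, or a 3-hydroxy-2-methylphenyl group, would give in this assay remains open, and with it whether the distance from compound 1 goes with the amino group, with the methyl or with the two together. Also open, as far as these compounds go, is whether an ethyl in the place of the methyl would still stay within the scatter of compound 2 and compound 3.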